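The source may hold more compounds than are shown below. What is called first, only, known or untested is meant among the compounds shown, and "the series" means these compounds.

Compound 1 `Nc1cccc(-c2cn3nc(-c4cccs4)sc3n2)c1` carries a free amine and is the weakest point of reference in this set. In a functional assay on FM3A cells (Mus musculus) for inhibition, read by cell counting, with a stated time of 2 days (a lower number here means a stronger inhibitor, a higher number a weaker inhibitor), compound 1 gives only a limit, > 250000 nM, which is the line (the limit of > 250000 nM in this assay, at which 1 of the 3 values shown sits). Compound 2 `C=C(Br)C(=O)Nc1cccc(-c2cn3nc(-c4cccs4)sc3n2)c1` gives 370 nM, so that an at least 670-fold lower number from compound 1 to compound 2 (2.82 log units; beyond the scatter). Compound 3 `C=C(Br)C(=O)Nc1cccc(-c2cn3nc(-c4ccc(OC)cc4)sc3n2)c1` gives 890 nM, and a 2.4-fold higher number from compound 2 to compound 3 (0.38 log units; beyond the scatter). Compound 4 `Cc1ccc(-c2nn3cc(-c4cccc(N)c4)nc3s2)cc1` differs from compound 1 in that (4-methylphenyl in place of thiophen-2-yl on an aromatic carbon). For the measured compounds named here, the only measured aryl swap, a 2.4-fold higher number from compound 2 to compound 3 (0.38 log units; beyond the scatter), was modest and was made on an amide, whereas compound 1 sits at the limit with no amide, and no aryl swap on an amine has been measured. Compound 4 is therefore expected to remain at the limit, giving an estimated 250000 nM within 80000 nM to 300000 nM, a step of a number no higher from compound 1 to compound 4 (the limit leaves the size open).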

Compound 4, half-maximal inhibitory concentration: 5800 nM
Estimate against measurement, compound 4: 43-fold (1.63 log units) above, and the stated range ends above it.
By their numbers in this assay, from the lowest: compound 2; then compound 3; then compound 4. At a limit, above all of these: compound 1.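

With the free amine in place, the aromatic carbon next to the ring nitrogen and next to the ring sulfur proves sensitive to its aryl group: 4-methylphenyl in place of thiophen-2-yl gives an at least 43-fold lower number from compound 1 to compound 4 (1.63 log units; beyond the scatter). The aryl swap on the amide, a different pair of groups, gave only a 2.4-fold higher number from compound 2 to compound 3 (0.38 log units; beyond the scatter). Compound 1 stands at a limit and not at a number, which leaves the full size of the new step open: the limit of > 250000 nM in this assay, at which 1 of the 4 values shown sits. The compounds shown leave open how 4-methylphenyl behaves with the (1-bromoethenyl)carbonyl group on the nitrogen, and whether 4-chlorophenyl or a carboxylic acid at this carbon would be tolerated.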